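A few compounds are considered here, and "the series" means these few. Any claim that something is new, unique, unknown or untested is made for them only; others in the source may bear on it.

Compound 1 `CCOC(=O)c1c(-c2cccc(OC)c2)[nH]c2cc(OC)c(F)cc2c1=O`: > 21500 nM (a limit)
Compound 2 `CCOC(=O)c1c(-c2cccc(-c3ccccc3Cl)c2)[nH]c2cc(OC)c(F)cc2c1=O`: > 21500 nM (a limit)
Compound 3 `CCOC(=O)c1c(-c2cccc(Oc3c(C)cccc3C)c2)[nH]c2cc(OC)c(F)cc2c1=O`: > 21500 nM (a limit)

All three values come from an ADME assay on HepG2 cells (Homo sapiens) for cytotoxicity, read by luminescence, with a stated time of 72 h; a higher number here means that more compound is needed for the effect, a lower number that less compound is needed. Compound 3 has no number here, only the limit > 21500 nM. That places it with the other two compounds at the limit of > 21500 nM in this assay, at which 3 of the 3 values shown sit.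

Compound 4 `CCOC(=O)c1c(-c2cccc(-c3nc(C)c(C)s3)c2)[nH]c2cc(OC)c(F)cc2c1=O` carries 4,5-dimethyl-1,3-thiazol-2-yl in place of 2,6-dimethylphenoxy on an aromatic carbon.

The closest measured comparison is a step that the two limits leave unreadable from compound 2 to compound 3, since there too 2,6-dimethylphenoxy is exchanged for another group on an aromatic carbon. The other two comparisons are a step that the two limits leave unreadable from compound 1 to compound 2 and a step that the two limits leave unreadable from compound 1 to compound 3. None of the three has a size that can be read, so they offer no measured effect to carry over, and no direction can be assigned. All three compounds nevertheless remain at the limit in this assay, whichever of these groups they carry.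

The estimated change is a number no higher from compound 3 to compound 4 (the limit leaves the size open), with nothing expected beyond the scatter. Compound 4 is expected at about 21500 nM, with an estimated range from 10000 nM to 40000 nM.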

Compound 4, half-maximal effective concentration: > 21500 nM
Compound 4: only a limit was reported; the forecaster's own chance of this, stated with the estimate: 85%; the middle value lies on the limit itself.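

In this assay compound 4, like compound 1, compound 2 and compound 3, is reported only as a limit, so no step among these four compounds can be read. The compounds shown leave open at what concentration any of them would reach the half-maximal effect, and whether the exchanged groups differ at all.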